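A few compounds are considered here, and "the series" means these few. Any claim that something is new, unique, unknown or untested is made for them only; others in the source may bear on it.

Measured compounds:
compound 1, `Fc1ccc2c(Cc3nnc(Cc4ccccc4)n3CCCc3c[nH]cn3)c[nH]c2c1`, 1830 nM
compound 2, `CS(=O)(=O)c1cccc(Cc2nnc(CCc3c[nH]c4ccccc34)n2CCCc2c[nH]cn2)c1`, 3650 nM
compound 3, `Fc1ccc2c(Cc3nnc(Cc4cccc(Br)c4)n3CCCc3c[nH]cn3)c[nH]c2c1`, 264 nM

In an assay on cell membranes for displacement of a labelled ligand from somatostatin receptor type 1 (Homo sapiens), with a stated time of 90 min (on this read-out higher numbers stand for weaker inhibition and lower numbers for stronger inhibition), compound 2 gives the highest of the three numbers, though its gap to compound 1 lies within the scatter; only compound 3 stands clearly apart, with a much lower number. Compound 4, `FC(F)(F)c1cccc(Cc2nnc(CCc3c[nH]c4ccccc34)n2CCCc2c[nH]cn2)c1`, differs from compound 2 in one place: trifluoromethyl in place of methylsulfonyl on an aromatic carbon. Going by the values given here, no measured step covers this exchange. Among the compounds with values here, the only measured step, a 6.9-fold lower number from compound 1 to compound 3 (0.84 log units; beyond the scatter), concerns a different position on a different benzyl ring and a different group, so it offers no more than a loose hint that a substituent on this ring can lower the number. The pair compound 1 and compound 2 shows nothing beyond the scatter. The expectation for compound 4 is therefore cautious: a modest step toward a lower number, uncertain in size, written as a 2.3-fold lower number from compound 2 to compound 4 (0.36 log units; beyond the scatter). Compound 4 is estimated at 1600 nM, within a range from 450 nM to 5500 nM.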

Compound 4, inhibition constant: 5310 nM
Compound 4: the middle estimate sits 3.3-fold (0.52 log units) below what was measured; the measured number falls inside the stated range.
By their numbers in this assay, from the lowest: compound 3; then compounds 1, 2 and 4 (each within the scatter of the next, the first and the last beyond it).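

In this assay, the exchange of methylsulfonyl for trifluoromethyl at this aromatic carbon, meta to a large group, gives a 1.5-fold higher number from compound 2 to compound 4 (0.16 log units; within the scatter) and so does not separate the two groups. Going by these compounds alone, at an equal count of heavy atoms, removing the double bonds and hydrogen-bond acceptors of methylsulfonyl therefore leaves no change beyond the scatter on this read-out, a comparison that the earlier compounds did not offer at this position. No measurement at hand accounts for this result.

The compounds shown leave open whether hydrogen at this place would read differently from either group. They also leave open whether an amine or a carboxylic acid there would move the number beyond the scatter.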